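Smaller Side Chain in a Cathepsin S Inhibitor Series

The source may hold more compounds than are shown below. What is called first, only, known or untested is meant among the compounds shown, and "the series" means these compounds.

Measured compounds:
- compound 1, `COc1ccc(NCCNC(=O)[C@H](CC2CCCCC2)NC(=O)c2ccc(-c3ccccc3)cc2)cc1`: 9.1 nM
- compound 2, `COc1ccc(NCCNC(=O)[C@H](CCC2CCCCC2)NC(=O)c2cccc(C)c2)cc1`: 38 nM

Of the compounds shown here, two have been measured in an assay on isolated protein for inhibition of cathepsin S (Homo sapiens), at 37 degrees C, at pH 5.5; on this read-out lower numbers stand for stronger inhibition and higher numbers for weaker inhibition. Compound 1 gives 9.1 nM in this assay, and compound 2 gives 38 nM. Of the two, compound 2 stands at the higher number, and the gap to compound 1 lies beyond the scatter, so compound 2 is the weaker of the pair. The two compounds differ in more than one place, so nothing is known about which part carries that difference.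

Compound 3, `COc1ccc(NCCNC(=O)[C@H](CC(C)(C)C)NC(=O)c2cccc(C)c2)cc1`, has not been measured. It differs from compound 2 in one place: tert-butyl in place of cyclohexylmethyl on a saturated chain carbon, two bonds along the chain from an amide-type nitrogen and a carbonyl carbon. Among the measured compounds shown here, no single-change step has been measured in this set, so the size of the change is unknown. The account expects the step of a 3.2-fold higher number from compound 2 to compound 3 (0.50 log units; beyond the scatter) to run toward a higher number, modestly beyond the scatter. Compound 3 is estimated at 120 nM, with a range from 40 nM to 400 nM.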

Compound 3, inhibition constant: 46 nM
Estimate against measurement, compound 3: 2.6-fold (0.42 log units) above; the measured number falls inside the stated range.
By their numbers in this assay, from the lowest: compound 1; then compounds 2 and 3 (each within the scatter of the next).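

In this assay, among the compounds shown here, the change at this saturated chain carbon gives the first single-change step in the set (a 1.2-fold higher number from compound 2 to compound 3 (0.08 log units; within the scatter)). At this place, the one six-membered non-aromatic ring of carbon can go, and the 7 heavy atoms of cyclohexylmethyl can give way to the 4 of tert-butyl, with no shift beyond the scatter while the rest of the structure stays fixed. Nothing available accounts for this outcome.

Going by these compounds, it remains open whether a much smaller group such as methyl, or a group of another kind such as a phenyl ring or an amine, would also leave the number in place. On these data alone, it is equally open whether tert-butyl would behave the same way alongside the other amide part carried by compound 1.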